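The source may hold more compounds than are shown below. What is called first, only, known or untested is meant among the compounds shown, and "the series" means these compounds.

In an ADME assay on BHK cells (Mesocricetus auratus) for cytotoxicity, read by MTT assay, with a stated time of 96 h (on this read-out lower numbers stand for higher toxicity in this test and higher numbers for lower toxicity in this test), compound 1 `COc1ccc(-c2nc3cc(Cl)c(Cl)cc3[nH]2)cc1` gives 18000 nM. Among the measured compounds shown here, in the same test compound 2 `COc1ccc(-c2nc3cc(Cl)c(Cl)cc3[nH]2)c([N+](=O)[O-])c1` gives 80000 nM, the highest of the two numbers measured, and the one step between them is a 4.4-fold higher number from compound 1 to compound 2 (0.65 log units; beyond the scatter). Compound 3 `COc1ccc(-c2nc3cc(Cl)c(Cl)cc3[nH]2)c(N)c1` differs from compound 2 by amino in place of nitro on an aromatic carbon. For the measured compounds named here, only that single measured step bears on this change, and it concerns a different exchange, so no firm direction for compound 3 in this assay can be read from it. Compound 3 is therefore expected to give about 30000 nM, within a range from 10000 nM to 90000 nM. That estimate means an expected step of a 2.7-fold lower number from compound 2 to compound 3 (0.43 log units; beyond the scatter).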

Compound 3, half-maximal cytotoxic concentration: > 100000 nM
Compound 3: no number, only a limit; the forecaster's own chance of this, stated with the estimate: 10%; middle value at least 3.3-fold (0.52 log units) away from the limit.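

In this assay compound 3 gives no number, only a limit of the test: the limit of > 100000 nM in this assay, at which 1 of the 3 values shown sits. Amino in place of hydrogen gives an at least 5.5-fold higher number from compound 1 to compound 3 (0.74 log units; beyond the scatter), so on this carbon, ortho to a large group, amino as well as nitro stands clear of hydrogen. Amino in place of nitro gives an at least 1.2-fold higher number from compound 2 to compound 3 (0.09 log units; that floor lies within the scatter), so no order between these two groups can be read. On these data alone, how far compound 3 lies past its limit stays open. So does whether a methyl group, fluorine or an acetamide on this carbon would also give a higher number than hydrogen.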